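This account rests on a few compounds, and the source may have more. Where it says the series, first, only, none or still open, it means among the compounds named here.

- compound 1 `NC(=O)c1cc(Br)ccc1NC(=O)/C=C/c1cccc(Cl)c1` gives 25.5%
- compound 2 `Cc1ccccc1/C=C/C(=O)Nc1ccc(Br)cc1C(N)=O` gives 43.2%

In a functional assay on K562 cells (Homo sapiens) for antiproliferative activity, read by trypan blue exclusion, with a stated time of 48 h, tested at 10 uM (on this read-out lower numbers stand for less inhibition of growth and higher numbers for more inhibition of growth at the one concentration tested), compound 2 stands highest of the two measured compounds. The change to compound 3 `Cc1cccc(/C=C/C(=O)Nc2ccc(Br)cc2C(N)=O)c1` is 3-methylphenyl in place of 2-methylphenyl on a double-bonded chain carbon bound to a double-bonded chain carbon and keeps the same atoms. Within the data shown here, only one measured step bears on it, a number 17.7 percentage points higher from compound 1 to compound 2 (beyond the scatter), a modest step at the same place. It swapped the group and not merely its position, so it is a weak guide. The expected change is small and slightly downward, not clearly beyond the scatter: a number 6.2 percentage points lower from compound 2 to compound 3 (within the scatter) is the estimated step. For compound 3 the estimated value is 37%, with an expected range from 21% to 53%.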

Compound 3, percent growth inhibition at one concentration: 43.8%
The estimate for compound 3 lay 6.8 percentage points below the measured number; the measured number falls inside the stated range.
By their numbers in this assay, from the lowest: compound 1; then compounds 2 and 3 (each within the scatter of the next).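

Moving to 3-methylphenyl in place of 2-methylphenyl in this assay gives a number 0.6 percentage points higher from compound 2 to compound 3 (within the scatter) and does not separate the two methyl placements. Methyl in place of chloro on an aromatic carbon gives a number 18.3 percentage points higher from compound 1 to compound 3 (beyond the scatter) and involves no change of place, so the difference between the chloro and methyl compounds is now seen for a swap of group alone. Nothing available explains either step.

Still open, on these data alone, is what a methoxy group or an amine would give in place of this methyl. As far as these compounds go, whether the flat result between the two methyl placements holds at other concentrations also remains open.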